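The compounds below may be only part of what the source reports. "The series", "measured", "known", "first", "only" and "open" are said of these compounds alone.

Measured in a functional assay, with a stated time of 30 min, in the absence of a further agent; on this read-out higher numbers stand for weaker inhibition and lower numbers for stronger inhibition:
- compound 1 `O=C(Nc1nnc(-c2cccc(O)c2O)s1)c1ccc(Cl)cc1`: 30200 nM
- compound 2 `O=C(COc1ccccc1)Nc1nnc(-c2cccc(O)c2O)s1`: 16600 nM
- compound 3 `Cc1ccc(C(=O)Nc2nnc(-c3ccc(O)c(O)c3)s2)cc1`: 34000 nM

Compound 2 carries the lowest number of the three in this assay, but only narrowly. Against compound 1 the measured change is a 1.8-fold lower number from compound 1 to compound 2 (0.26 log units; within the scatter), so these two cannot be told apart. Only compound 3 stands beyond the scatter from compound 2, and only just.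

The next compound is compound 4 `O=C(COc1ccccc1)Nc1nnc(-c2ccc(O)c(O)c2)s1`, which keeps the phenoxymethyl side of compound 2 and changes the other end: 3,4-dihydroxyphenyl in place of 2,3-dihydroxyphenyl on an aromatic carbon. Put simply, 3,4-dihydroxyphenyl stands in place of 2,3-dihydroxyphenyl on an aromatic carbon.

Among the compounds with values here, no measured step covers this exchange directly. Within the data shown here, the one step available, a 1.8-fold lower number from compound 1 to compound 2 (0.26 log units; within the scatter), concerns a different place in the molecule. The closest indirect evidence comes from two values. Compound 1, with the 2,3-dihydroxyphenyl, gives 30200 nM, and compound 3, with the 3,4-dihydroxyphenyl, gives 34000 nM. These lie within the scatter of each other, so no step beyond the scatter is expected, though three compounds are thin support for this. The expected change is a 1.2-fold higher number from compound 2 to compound 4 (0.08 log units; within the scatter). For compound 4 the estimated value is 20000 nM, with an expected range from 9000 nM to 42000 nM.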

Compound 4, half-maximal inhibitory concentration: 36100 nM
Beside the measured number, compound 4's estimate is 1.8-fold (0.26 log units) below it, within the range that was stated.
By their numbers in this assay, from the lowest: compounds 2, 1, 3 and 4 (each within the scatter of the next, the first and the last beyond it).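

Within the data shown here, with the phenoxymethyl side held fixed, this is the first direct reading of the exchange on the aromatic carbon of the shared core: 3,4-dihydroxyphenyl in place of 2,3-dihydroxyphenyl gives a 2.2-fold higher number from compound 2 to compound 4 (0.34 log units; beyond the scatter), a modest loss of inhibition in this assay that shows the arrangement of the two hydroxyl groups can matter at this position. By contrast, the exchange on the carbonyl carbon within the 3,4-dihydroxyphenyl pair gives a 1.1-fold higher number from compound 3 to compound 4 (0.03 log units; within the scatter), so here, as with a 1.8-fold lower number from compound 1 to compound 2 (0.26 log units; within the scatter) in the 2,3-dihydroxyphenyl pair, the change of side group cannot be told from scatter. No measurement at hand accounts for the difference between the two hydroxyl arrangements.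

On these data alone, the step at the dihydroxyphenyl position rests on a single pair, so it remains open whether the same exchange would give a step of this size with 4-chlorophenyl or 4-methylphenyl on the carbonyl carbon. Also open, as far as these compounds go, is how a methoxy group or an amine in place of either hydroxyl group would read in this assay, and whether a longer chain on the carbonyl carbon would move the number at all.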